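Swapping the side-chain ring on compound 2

A few compounds are considered here, and "the series" means these few. Any claim that something is new, unique, unknown or untested is made for them only; others in the source may bear on it.

Values in an ADME assay on the whole organism (Rattus norvegicus), with a stated time of 6 h, at a dose of 10 mg/kg by the oral route; on this read-out higher numbers stand for higher exposure at the dose given and lower numbers for lower exposure:
- Compound 1 `CN(C)CCN(C(=O)Nc1ccc(C(F)(F)F)c(F)c1)c1ccc(-c2cccc(C#N)c2)cc1`: 4800 ng.h/mL
- Compound 2 `N#Cc1cccc(-c2ccc(N(CCN3CCCC3)C(=O)Nc3ccc(C(F)(F)F)c(F)c3)cc2)c1`: 967 ng.h/mL

Of the two measured compounds, compound 2 has the lower number, at 967 ng.h/mL. The next compound, compound 3 `CN1CCN(CCN(C(=O)Nc2ccc(C(F)(F)F)c(F)c2)c2ccc(-c3cccc(C#N)c3)cc2)CC1`, has not yet been measured. It carries 4-methylpiperazin-1-yl in place of pyrrolidin-1-yl on a saturated chain carbon, two bonds along the chain from an amide-type nitrogen.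

Among the measured compounds shown here, only one measured step bears on this change, and it falls at the same place: a 5.0-fold lower number from compound 1 to compound 2 (0.70 log units; beyond the scatter), where pyrrolidin-1-yl took the place of dimethylamino. That step shows the number can move with the group at this place. It involves neither 4-methylpiperazin-1-yl nor any six-membered ring, so it gives no firm direction. No step beyond the scatter is expected in this assay. The estimated step is a 1.2-fold higher number from compound 2 to compound 3 (0.09 log units; within the scatter). For compound 3 the estimate is 1200 ng.h/mL, with an expected range from 350 ng.h/mL to 4500 ng.h/mL.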

Compound 3, area under the concentration-time curve: 542 ng.h/mL
For compound 3 the middle estimate is 2.2-fold (0.35 log units) above the measured one, within the range that was stated.
By their numbers in this assay, from the lowest: compounds 3 and 2 (each within the scatter of the next); then compound 1.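

In this assay, the change from the five-membered pyrrolidin-1-yl ring to the six-membered 4-methylpiperazin-1-yl ring, with its two nitrogens, makes no clear difference at this position on the chain (a 1.8-fold lower number from compound 2 to compound 3 (0.25 log units; within the scatter)). The gap to the open-chain dimethylamino group is larger and clear (an 8.9-fold lower number from compound 1 to compound 3 (0.95 log units; beyond the scatter)), so among these three compounds, both ring-bearing compounds lie beyond the scatter from compound 1, and none goes against this. Nothing measured here explains these numbers.

The compounds shown leave open whether that gap follows from having a ring at all or from something specific to these two rings. A piperidin-1-yl or morpholin-4-yl ring, or an open-chain diethylamino group, at the same place would help to separate those two readings.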